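Trimming the Piperazine Tail of a Benzimidazole Anilide

The source may hold more compounds than are shown below. What is called first, only, known or untested is meant among the compounds shown, and "the series" means these compounds.

Compound 1 `CN1CCN(CC(=O)Nc2ccc(-c3nc4cc(C(F)(F)F)ccc4n3C)cc2)CC1` was tested in an ADME assay on MT4 cells (Homo sapiens) for cytotoxicity, read by MTT assay, with a stated time of 96 h (a higher number here means that more compound is tolerated, a lower number that less compound is tolerated), where compound 1 gives 22000 nM. Of the two plain numbers recorded, this is the highest, and the nearest neighbour is compound 2 `O=C(CN1CCCC1)Nc1ccc(-c2nc3cc(C(F)(F)F)ccc3[nH]2)cc1`, which in this assay gives 18000 nM; the two sit within the scatter of one another, so neither can be called better tolerated. Compound 3 `CC(=O)Nc1ccc(-c2nc3cc([N+](=O)[O-])ccc3[nH]2)cc1` yields only a limit rather than a number, (the limit of > 100000 nM in this assay, at which 1 of the 3 values shown sits), and in this assay compound 3 is recorded as > 100000 nM.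

Compound 4 `CCC(=O)Nc1ccc(-c2nc3cc(C(F)(F)F)ccc3n2C)cc1` remains to be measured. It differs from compound 1 in a single place: methyl in place of 4-methylpiperazin-1-yl on a saturated chain carbon bound to a carbonyl carbon. Going by the values given here, no step between measured compounds covers this change, so its effect has to be expected rather than read off. Because compound 1 gives 22000 nM, compound 4 is expected to land at a similar or somewhat higher tolerated concentration, a modest step that may not exceed the scatter. The step from compound 1 to compound 4 is thus estimated as a 1.8-fold higher number from compound 1 to compound 4 (0.26 log units; within the scatter). Compound 4 is estimated at 40000 nM, within a range from 12000 nM to 130000 nM.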

Compound 4, half-maximal cytotoxic concentration: 8000 nM
Estimate against measurement, compound 4: 5.0-fold (0.70 log units) above; the whole stated range lies above it.
By their numbers in this assay, from the lowest: compound 4; then compounds 2 and 1 (each within the scatter of the next). At a limit, above all of these: compound 3.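

In this assay, the change at this position has a measurable effect: methyl in place of 4-methylpiperazin-1-yl on a saturated chain carbon bound to a carbonyl carbon gives a 2.8-fold lower number from compound 1 to compound 4 (0.44 log units; beyond the scatter). Going by these compounds alone, the earlier compounds offered no step between measured compounds, so this pair is the first to show that the tail bears on how much compound the cells tolerate, with the smaller group on the less tolerated side. Nothing measured here gives a reason for this step, and a single pair sets no trend.

On these data alone, it remains open whether the piperazine ring itself matters or whether a simple dimethylamino group, a morpholine ring or a carboxylic acid on the same carbon would behave like 4-methylpiperazin-1-yl. A longer alkyl chain in place of methyl would show whether the number keeps moving with the size of the group.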